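Reversing the One Stereocentre of Compound 3

The source may hold more compounds than are shown below. What is called first, only, known or untested is meant among the compounds shown, and "the series" means these compounds.

Going by the values given here, in a functional assay on A-375 cells (Homo sapiens) for antiproliferative activity (on this read-out higher numbers stand for weaker inhibition and lower numbers for stronger inhibition), compound 3 `O=C(Nc1ccc(-c2ccc[nH]2)cc1)[C@@H]1CCCN(Cc2ccc(F)c(F)c2)C1` gives 18000 nM, the highest number of the three measured so far. Compound 2 `O=C(Nc1ccc(-c2ccc[nH]2)cc1)C1CCCN(Cc2ccc(F)c(F)c2)C1` gives 360 nM, and compound 1 `O=C(Nc1ccc(-c2cscn2)cc1)[C@H]1CCCN(Cc2ccc(F)c(F)c2)C1` gives 190 nM. Compound 4 `O=C(Nc1ccc(-c2ccc[nH]2)cc1)[C@H]1CCCN(Cc2ccc(F)c(F)c2)C1` is still unmeasured, and it differs from compound 3 as follows: the two compounds have the same atoms and bonds and differ only in configuration as drawn: 1 of 1 stereo elements differ; a stereocentre at a saturated ring carbon is drawn R in compound 3 and S in compound 4. Among the compounds with values here, the one measured step bearing on this is a 50-fold higher number from compound 2 to compound 3 (1.70 log units; beyond the scatter), which goes with the fact that one of compounds 2 and 3 is drawn with a defined configuration and the other without, at the place where they differ. If compound 2, at 360 nM, holds both configurations, most of its activity should lie in the form drawn S, so a large fall in the number is expected in this assay. The expected change is a 95-fold lower number from compound 3 to compound 4 (1.98 log units; beyond the scatter). Compound 4 is estimated at 190 nM, with an expected range of 90 nM to 400 nM.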

Compound 4, half-maximal inhibitory concentration: 190 nM
Beside the measured number, compound 4's estimate shows no gap at the digits printed, within the range that was stated.
By their numbers in this assay, from the lowest: compounds 1, 4 and 2 (each within the scatter of the next); then compound 3.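

In this assay, a large step, a 95-fold lower number from compound 3 to compound 4 (1.98 log units; beyond the scatter), now rests on two defined configurations at this ring carbon alone: the fact that compounds 3 and 4 differ only in the configuration as drawn. The S form and the form drawn without a configuration cannot be told apart, with a 1.9-fold lower number from compound 2 to compound 4 (0.28 log units; within the scatter). With the centre drawn S, 1H-pyrrol-2-yl and 1,3-thiazol-4-yl are not separated either, with no change at the digits printed from compound 1 to compound 4 (within the scatter).

From the compounds shown here alone, whether the 1,3-thiazol-4-yl series shows the same dependence on configuration stays open. So does how an amine or a carboxylic acid would read in place of these aromatic groups.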